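The source may hold more compounds than are shown below. What is called first, only, known or untested is meant among the compounds shown, and "the series" means these compounds.

Measured compounds:

- compound 1 `COCC(=O)N(Cc1ccc(OC)c(O)c1)c1cc(OC)c(OC)c(OC)c1`: 460 nM
- compound 2 `C/C=C/C(=O)N(Cc1ccc(OC)c(OC)c1)c1cc(OC)c(OC)c(OC)c1`: 39100 nM
- compound 3 `COc1cc(NCc2cccc(O)c2)cc(OC)c1OC`: 71300 nM

These three compounds were tested in a functional assay on KYSE-450 cells (Homo sapiens) for inhibition, read by MTT assay, with a stated time of 48 h; on this read-out lower numbers stand for stronger inhibition and higher numbers for weaker inhibition. Compound 1 gives the lowest number of the three, and both gaps to the others lie beyond the usual scatter: compound 2 sits far higher, and compound 3 higher still. The two weaker compounds each differ from compound 1 in more than one place, so no single change among the measured compounds can be followed.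

Compound 4 `COc1ccc(CN(C(=O)C2CC2)c2cc(OC)c(OC)c(OC)c2)cc1O` has not yet been measured. It differs from compound 1 in one place: cyclopropyl in place of methoxymethyl on a carbonyl carbon. Going by the values given here, no measured pair shows this exchange, so its effect cannot be read from the data. Since compound 1 stands alone at the strong end, and the group that enters is of similar size to the one that leaves, a modest step is expected, more likely toward weaker inhibition than stronger, and quite possibly not beyond the scatter. Compound 4 is therefore estimated at 900 nM in this assay, with a range from 300 nM to 3000 nM, which corresponds to an expected step of a 2.0-fold higher number from compound 1 to compound 4 (0.29 log units; within the scatter).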

Compound 4, half-maximal inhibitory concentration: 80 nM
For compound 4 the middle estimate is 11-fold (1.05 log units) above the measured one; the measured number lies below the stated range.
By their numbers in this assay, from the lowest: compound 4; then compound 1; then compounds 2 and 3 (each within the scatter of the next).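

In this assay, cyclopropyl in place of methoxymethyl on a carbonyl carbon gives a 5.8-fold lower number from compound 1 to compound 4 (0.76 log units; beyond the scatter). Going by these compounds alone, this is the first single change that can be followed in this set, and it shows that the group on this carbonyl carbon matters for the read-out, even though both groups have the same count of heavy atoms. It also shows that, within this pair, a low number does not depend on the hydrogen-bond acceptor counted in methoxymethyl, but no measurement here explains the step.

Within the data shown here, with only one pair, it remains open whether the ring or the loss of the oxygen drives the step. An isopropyl group on the same carbonyl carbon, all carbon but without a ring, would help to separate the two, and a cyclobutyl ring would show whether a larger ring is tolerated.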